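Halogen Swap on the Benzyl Group: Compound 3 to Compound 4

A few compounds are considered here, and "the series" means these few. Any claim that something is new, unique, unknown or untested is made for them only; others in the source may bear on it.

Compound 1, `O=C1/C(=C/c2ccccc2F)CN(C(=S)SCc2cn(Cc3ccc(F)cc3)nn2)C/C1=C\c1ccccc1F`, gives > 80000 nM in a functional assay on PC-3 cells (Homo sapiens) for cytotoxicity, read by MTT assay, with a stated time of 24 h; on this read-out higher numbers stand for weaker inhibition and lower numbers for stronger inhibition; this value is a limit of the assay rather than a number.
Compound 2, `COc1ccc(/C=C2\CN(C(=S)SCc3cn(Cc4ccccc4Cl)nn3)C/C(=C\c3ccc(OC)cc3)C2=O)cc1`, gives 60100 nM in this assay.
Compound 3, `Cc1ccc(/C=C2\CN(Cc3cn(Cc4cccc(Cl)c4)nn3)C/C(=C\c3ccc(C)cc3)C2=O)cc1`, gives 29300 nM in this assay.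

Of the two actual numbers, compound 3 has the lower one, and its gap to compound 2 lies beyond the usual scatter of repeated measurements. Compound 1 stands at a limit of the assay (the limit of > 80000 nM in this assay, at which 1 of the 3 values shown sits), so it gives no number to compare. Among the compounds with values here, all three compounds share the same core but differ in the groups around it, and no pair of them differs in one place only, so no measured step is available as a guide.

Compound 4, `Cc1ccc(/C=C2\CN(Cc3cn(Cc4ccccc4F)nn3)C/C(=C\c3ccc(C)cc3)C2=O)cc1`, is the next compound to be measured. It keeps everything of compound 3 except one change: 2-fluorophenyl in place of 3-chlorophenyl on a saturated chain carbon bound to an aromatic nitrogen. One halogen on the benzyl group is replaced by another, and its position on that ring also moves. With no measured step of this kind among these compounds, the expectation rests on the change being small and remote from the core.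

The step from compound 3 to compound 4 is expected to be small, a 1.0-fold higher number from compound 3 to compound 4 (0.01 log units; within the scatter), and to lie within the scatter. Compound 4 is therefore estimated to give 30000 nM in this assay, with a range from 12000 nM to 75000 nM.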

Compound 4, half-maximal inhibitory concentration: 8800 nM
The estimate for compound 4 lay 3.4-fold (0.53 log units) above the measured number; measured number below the stated range.
By their numbers in this assay, from the lowest: compound 4; then compound 3; then compound 2. At a limit, above all of these: compound 1.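

Replacing 3-chlorophenyl with 2-fluorophenyl gives a 3.3-fold lower number from compound 3 to compound 4 (0.52 log units; beyond the scatter) in this assay, and this is the first comparison among these compounds in which only one place differs, so it is the first direct sign that the group on this saturated chain carbon bound to an aromatic nitrogen can shift the number by more than the usual scatter on its own. Within the data shown here, the single step changes two things together, the identity of the halogen and its place on the ring, so it cannot say which of the two accounts for the lower number. Nothing measured among these compounds explains why the number falls.

Still open, on these data alone, is what each part of the change does alone, with only the halogen swapped or only its place on the ring moved. Also open, as far as these compounds go, is how a plain benzyl group, or a benzyl group carrying a methoxy group or an amine, would compare with the 2-fluorobenzyl group of compound 4, and whether this step would repeat with other groups on the shared core.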